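The source may report more compounds than this note shows. Statements on the series, on what has been measured and on what is new or still open speak of the compounds shown alone.

Compound 2 `Cc1nn(-c2ccccc2)cc1/C=N/Nc1nc(Nc2ccccc2)nc(Nc2ccc(S(N)(=O)=O)cc2)n1` and compound 1 `NS(=O)(=O)c1ccc(Nc2nc(N/N=C/c3ccc(C(F)(F)F)cc3)nc(Nc3ccccc3)n2)cc1` share one core and differ only in the group on a carbon with a double bond to nitrogen. In a functional assay on SK-OV-3 cells (Homo sapiens) for inhibition, read by sulforhodamine B assay, with a stated time of 48 h (a lower number here means a stronger inhibitor of growth, a higher number a weaker inhibitor of growth), compound 2 gives 2930 nM, and in the same assay compound 1 gives 3660 nM; the step of a 1.2-fold lower number from compound 1 to compound 2 (0.10 log units; within the scatter) leaves the two numbers level with each other, so compound 2 stands at no real distance from its only companion. Compound 3 `NS(=O)(=O)c1ccc(Nc2nc(N/N=C/c3ccccn3)nc(Nc3ccccc3)n2)cc1` differs from compound 2 in one place: pyridin-2-yl in place of 3-methyl-1-phenyl-1H-pyrazol-4-yl on a carbon with a double bond to nitrogen. Going by the values given here, the only measured step that bears on this exchange is the one just described, and it stayed within the scatter. On that single precedent no step beyond the scatter is expected in this assay, and the move from compound 2 to compound 3 is estimated at a 1.2-fold higher number from compound 2 to compound 3 (0.08 log units; within the scatter). For compound 3 the value in this assay is expected near 3500 nM, with a range from 1200 nM to 10000 nM.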

Compound 3, concentration for 50% growth inhibition: 840 nM
Estimate against measurement, compound 3: 4.2-fold (0.62 log units) above, and the stated range ends above it.
By their numbers in this assay, from the lowest: compound 3; then compounds 2 and 1 (each within the scatter of the next).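

At the carbon with a double bond to nitrogen, the group can clearly shift the number in this assay: the exchange for pyridin-2-yl gives a 3.5-fold lower number from compound 2 to compound 3 (0.54 log units; beyond the scatter), and measured against 4-(trifluoromethyl)phenyl it gives a 4.4-fold lower number from compound 1 to compound 3 (0.64 log units; beyond the scatter). The earlier step had suggested that this place was insensitive, but it only showed that 3-methyl-1-phenyl-1H-pyrazol-4-yl and 4-(trifluoromethyl)phenyl sit level with each other, whereas pyridin-2-yl, a single six-membered aromatic ring with 1 hetero atom, stands apart from both. Nothing measured here accounts for this separation.

The compounds shown leave open whether the step follows the ring nitrogen of pyridin-2-yl, its place in the ring, or simply the single small ring. A pyridin-3-yl, a pyridin-4-yl or an unsubstituted phenyl group on the same carbon would tell these readings apart.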